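This account rests on a few compounds, and the source may have more. Where it says the series, first, only, none or still open, it means among the compounds named here.

Compound 1 `O=[N+]([O-])c1ccc2[nH]c(Cc3ccc(Oc4ccccc4)cc3)nc2c1` gives 1200 nM in an assay on membranes from brain for binding affinity to Adrenergic receptor alpha-1 (Rattus norvegicus); on this read-out lower numbers stand for stronger inhibition and higher numbers for weaker inhibition.
Compound 2 `N#Cc1ccc2[nH]c(Cc3ccc(Oc4ccccc4)cc3)nc2c1` gives 3400 nM in this assay.
Compound 3 `CS(=O)(=O)Nc1ccc2[nH]c(Cc3ccc(Oc4ccccc4)cc3)nc2c1` gives 4000 nM in this assay.

Compound 3 stands highest of the three numbers, though its gap to compound 2 is within the scatter, with a 1.2-fold higher number from compound 2 to compound 3 (0.07 log units; within the scatter); only compound 1 sits clearly apart, with a 3.3-fold higher number from compound 1 to compound 3 (0.52 log units; beyond the scatter). Compound 4 `CCCS(=O)(=O)Nc1ccc2[nH]c(Cc3ccc(Oc4ccccc4)cc3)nc2c1` differs from compound 3 by ethyl in place of hydrogen on a saturated chain carbon bound to a sulfonyl sulfur. Within the data shown here, no measured step touches this chain: all three steps exchanged the group on the aromatic carbon, and the sulfonyl chain was never varied. With nothing to guide a direction, the expected step is no change at the digits printed from compound 3 to compound 4 (within the scatter), inside the scatter. Compound 4 is therefore estimated at 4000 nM, with a range from 1500 nM to 11000 nM.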

Compound 4, half-maximal inhibitory concentration: 4800 nM
Estimate against measurement, compound 4: 1.2-fold (0.08 log units) below; the measured number falls inside the stated range.
By their numbers in this assay, from the lowest: compound 1; then compounds 2, 3 and 4 (each within the scatter of the next).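

In this assay ethyl in place of hydrogen on a saturated chain carbon bound to a sulfonyl sulfur gives the first read on this chain, and the step stays within the scatter (a 1.2-fold higher number from compound 3 to compound 4 (0.08 log units; within the scatter)). The (propylsulfonyl)amino group also stays within the scatter of the cyano group (a 1.4-fold higher number from compound 2 to compound 4 (0.15 log units; within the scatter)), while the nitro group remains clearly apart (a 4.0-fold higher number from compound 1 to compound 4 (0.60 log units; beyond the scatter)). No evidence is available that bears on this result.

Going by these compounds, whether a longer chain or a phenyl ring on the sulfonyl sulfur would shift the number remains open. So does the effect of an amine or a carboxylic acid in place of nitro on the aromatic carbon.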